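Shifting the chain between the core and the piperazine

A few compounds are considered here, and "the series" means these few. Any claim that something is new, unique, unknown or untested is made for them only; others in the source may bear on it.

Compound 1 `CN1CCN(CCCNC(=O)n2c(=O)n(C3CC3)c3ccccc32)CC1` is one of two related compounds tested in an assay on isolated protein (striatum) for binding affinity to 5-hydroxytryptamine receptor 4 (Cavia porcellus), read by radioligand binding; on this read-out higher numbers stand for weaker inhibition and lower numbers for stronger inhibition. In this assay compound 1 gives 39.7 nM, the lowest of the two numbers. The other, compound 2 `CC(C)n1c(=O)n(C(=O)NCCN2CCN(C)CC2)c2ccccc21`, gives 91.1 nM in this assay, a higher number that lies beyond the usual scatter of repeated measurements. Going by the values given here, no direct single-point step between these two has been worked out, so only the two values themselves can be compared.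

Compound 3 `CCCN1CCN(CCNC(=O)n2c(=O)n(C3CC3)c3ccccc32)CC1` has not yet been measured. It differs from compound 1 in one place: 4-propylpiperazin-1-yl in place of (4-methylpiperazin-1-yl)methyl on a saturated chain carbon, two bonds along the chain from an amide-type nitrogen. Because compound 1 gives 39.7 nM in this assay, compound 3 is expected to land near it, with a modest move toward a higher number estimated at a 1.5-fold higher number from compound 1 to compound 3 (0.18 log units; within the scatter). The value of compound 3 in this assay is estimated at 60 nM, with a likely range from 25 nM to 150 nM.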

Compound 3, inhibition constant: 8.2 nM
Estimate against measurement, compound 3: 7.3-fold (0.86 log units) above; measured number outside the range, below it.
By their numbers in this assay, from the lowest: compound 3; then compound 1; then compound 2.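

In this assay, swapping the group gives a 4.8-fold lower number from compound 1 to compound 3 (0.68 log units; beyond the scatter), so this place on the chain responds clearly to the change, and the step lies beyond the scatter. The group that leaves and the group that enters share the same kind of ring and the same counts of hydrogen-bond donors and acceptors, and neither carries a net charge, so those features do not separate them. Two things differ at once, however: the methyl on the piperazine becomes a propyl, and the extra methyl carbon of the leaving group is gone from the chain.

Going by these compounds, it remains open which of these two differences carries the step, and whether a butyl on the piperazine would continue the trend. Nothing measured here accounts for the step.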